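The source may hold more compounds than are shown below. What is called first, only, known or untested is meant among the compounds shown, and "the series" means these compounds.

Measured in an ADME assay on THP-1 cells (Homo sapiens) for cytotoxicity; on this read-out lower numbers stand for higher toxicity in this test and higher numbers for lower toxicity in this test:
- Compound 1 `COc1ccc(NC(=O)c2ccsc2NC(=O)C(F)(F)F)cc1`: > 50000 nM (a limit of the assay, not a number)
- Compound 2 `N#Cc1ccc(NC(=O)c2c(NC(=O)C(F)(F)F)sc3c2CCCCC3)cc1`: 9110 nM
- Compound 3 `COc1ccc(NC(=O)c2c(NC(=O)C(F)(F)F)sc3c2CCCC3)cc1`: > 50000 nM (a limit of the assay, not a number)

Compound 2 is the only one of the three with an actual number, at 9110 nM. The other two readings stand at the limit of > 50000 nM in this assay, at which 2 of the 3 values shown sit.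

Compound 4 `CC(C)(C)NC(=O)c1c(NC(=O)C(F)(F)F)sc2c1CCCCC2` has not yet been measured. It carries tert-butyl in place of 4-cyanophenyl on an amide-type nitrogen. Among the measured compounds shown here, no measured pair of compounds isolates this change, so its size cannot be read from the data directly. Compound 2 at 9110 nM is the only one of the three with an actual number, and a modest move to higher numbers in this assay, meaning lower toxicity in this test, is therefore expected. The estimated 2.4-fold higher number from compound 2 to compound 4 (0.38 log units; beyond the scatter) is modest and carries wide uncertainty, and a reading at the limit would not be a surprise. The estimate for compound 4 is 22000 nM, with an expected range of 9000 nM to 50000 nM.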

Compound 4, half-maximal cytotoxic concentration: > 50000 nM
Compound 4 was reported as a limit; the forecaster's own chance of this, stated with the estimate: 35%; middle value at least 2.2-fold (0.35 log units) away from the limit.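

In this assay, among the compounds shown here, putting tert-butyl in place of 4-cyanophenyl on an amide-type nitrogen gives an at least 5.4-fold higher number from compound 2 to compound 4 (0.73 log units; beyond the scatter) and provides the first measured step at this position. Compound 4 reads > 50000 nM, a limit of the assay and not a number. For the compounds shown here, the step's full size therefore cannot be read, and compound 2 remains the only compound with an actual number: the limit of > 50000 nM in this assay, at which 3 of the 4 values shown sit.

The compounds shown leave open whether the lower number of compound 2 goes with the nitrile or with the aromatic ring of 4-cyanophenyl. An unsubstituted phenyl or a cyclohexyl on the same amide-type nitrogen would separate these two parts of the change.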